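Second sulfonamide arm on the shared core: expectation

A few compounds are considered here, and "the series" means these few. Any claim that something is new, unique, unknown or untested is made for them only; others in the source may bear on it.

Compound 3 `O=S(=O)(Nc1ccc(-c2nc3ccccc3o2)cc1)c1ccccc1O` carries a 2-hydroxyphenyl on the sulfonyl sulfur where compound 1 `O=S(=O)(Nc1ccc(-c2nc3ccccc3o2)cc1)c1cccs1` carries a thiophen-2-yl. In an assay on cells for inhibition of HSP60/HSP10 (Homo sapiens), with a stated time of 60 min (a higher number here means a weaker inhibitor, a lower number a stronger inhibitor), compound 1 gives 63000 nM. For compound 3 the result in this assay is a limit, > 100000 nM, and not a number. The step of an at least 1.5-fold higher number from compound 1 to compound 3 (0.20 log units; that floor lies within the scatter) thus rests on (the limit of > 100000 nM in this assay, at which 1 of the 3 values shown sits). Compound 2 `O=S(=O)(Nc1ccc2oc(-c3ccccc3)nc2c1)c1ccccc1O`, in which a ((2-hydroxyphenyl)sulfonyl)amino sits on the fused system of two rings, gives 85000 nM in this assay. Among the three measured compounds, compound 3 stands at the limit, while its two companions sit at numbers close to it.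

Compound 4 `O=S(=O)(Nc1ccc(-c2nc3cc(NS(=O)(=O)c4ccccc4O)ccc3o2)cc1)c1ccccc1O` differs from compound 3 by ((2-hydroxyphenyl)sulfonyl)amino in place of hydrogen on an aromatic carbon. Within the data shown here, no measured step matches this change: the only step, an at least 1.5-fold higher number from compound 1 to compound 3 (0.20 log units; that floor lies within the scatter), concerns the sulfonyl sulfur and has only a floor. Compound 2, which carries the entering group alone, gives 85000 nM in this assay, a weak result. Compound 4 is therefore expected to remain in the weak range. The step is expected to be a number no higher from compound 3 to compound 4 (the limit leaves the size open), not beyond the scatter. The expected value for compound 4 in this assay is 100000 nM, within 40000 nM to 250000 nM, and a limit rather than a number is about as likely as not.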

Compound 4, half-maximal inhibitory concentration: 18000 nM
Compound 4: the middle estimate sits 5.6-fold (0.74 log units) above what was measured; measured number below the stated range.
By their numbers in this assay, from the lowest: compound 4; then compounds 1 and 2 (each within the scatter of the next). At a limit, above all of these: compound 3.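

In this assay, among these compounds, ((2-hydroxyphenyl)sulfonyl)amino in place of hydrogen on this aromatic carbon of the fused system of two rings gives the first step that is printed as beyond the scatter: an at least 5.5-fold lower number from compound 3 to compound 4 (0.74 log units; beyond the scatter). The same group added to compound 2 at its other place gives a 4.7-fold lower number from compound 2 to compound 4 (0.67 log units; beyond the scatter), so compound 4, with both arms, is stronger in this assay than either one-armed compound, compound 2 or compound 3. The first of these steps has only a floor, since compound 3 gives a limit and not a number: the limit of > 100000 nM in this assay, at which 1 of the 4 values shown sits.

The compounds shown leave open whether the gain needs the 2-hydroxyphenyl on both arms, or whether a thiophen-2-yl on one or both sulfonyl sulfurs would serve as well. Also open, from the compounds shown here alone, is whether a smaller group on this aromatic carbon, such as an amine or a carboxylic acid, would give a similar step, or whether the whole ((2-hydroxyphenyl)sulfonyl)amino is required.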